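The compounds below may be only part of what the source reports. "The series", "measured", "known", "first", "only" and "open" are said of these compounds alone.

Three compounds share one core and differ only in the aryl group carried on the ring nitrogen. In an assay on HEK293 cells for inhibition of Voltage-dependent T-type calcium channel subunit alpha-1G (Homo sapiens), read by patch clamp (on this read-out higher numbers stand for weaker inhibition and lower numbers for stronger inhibition), compound 1 `CCCc1nc(-c2ccccc2)c(CNCCN2CCN(c3ccccc3Cl)CC2)o1` gives 4370 nM; compound 2 `CCCc1nc(-c2ccccc2)c(CNCCN2CCN(c3ccccc3C(F)(F)F)CC2)o1` gives 2100 nM; and compound 3 `CCCc1nc(-c2ccccc2)c(CNCCN2CCN(c3cccc(F)c3)CC2)o1` gives 3350 nM. Of these three numbers compound 3 holds the second highest, its gaps to the others being a 1.3-fold lower number from compound 1 to compound 3 (0.12 log units; within the scatter) and a 1.6-fold higher number from compound 2 to compound 3 (0.20 log units; within the scatter), both within the scatter. Going by the values given here, the only step that reaches beyond the scatter is a 2.1-fold lower number from compound 1 to compound 2 (0.32 log units; beyond the scatter), an exchange of the substituent on the aryl ring rather than of the aryl group as a whole.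

Compound 4 `CCCc1nc(-c2ccccc2)c(CNCCN2CCN(c3cccc(C)c3C)CC2)o1` introduces the change (2,3-dimethylphenyl in place of 3-fluorophenyl on an amine nitrogen in a ring). The two measured steps that swap the whole aryl group on that ring nitrogen both stayed within the scatter, so no step beyond the scatter is anticipated here, in either direction. The number expected for compound 4 in this assay is 3000 nM, with a range from 1200 nM to 7500 nM. That estimate means an expected step of a 1.1-fold lower number from compound 3 to compound 4 (0.05 log units; within the scatter).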

Compound 4, half-maximal inhibitory concentration: 1710 nM
For compound 4 the middle estimate is 1.8-fold (0.24 log units) above the measured one; the measured number falls inside the stated range.
By their numbers in this assay, from the lowest: compounds 4, 2, 3 and 1 (each within the scatter of the next, the first and the last beyond it).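

Unlike the aryl groups of compound 1, compound 2 and compound 3, the 2,3-dimethylphenyl group of compound 4 holds no halogen, yet in this assay the steps of a 2.0-fold lower number from compound 3 to compound 4 (0.29 log units; within the scatter) and a 1.2-fold lower number from compound 2 to compound 4 (0.09 log units; within the scatter) show no separation from those two compounds. The step of a 2.6-fold lower number from compound 1 to compound 4 (0.41 log units; beyond the scatter) is modest, but it shows that exchanging the whole aryl group on this ring nitrogen can reach beyond the scatter, which neither exchange leading to compound 3 did. Nothing given here accounts for this result.

The compounds shown leave open whether a single methyl group on the phenyl ring would read like the two in compound 4. They also leave open how a methoxy group or a nitrile on that ring would read.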